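A new end group on a growth inhibitor

The source may hold more compounds than are shown below. What is called first, only, known or untested is meant among the compounds shown, and "the series" means these compounds.

In a functional assay on DWD cells (Homo sapiens) for inhibition, read by sulforhodamine B assay (on this read-out lower numbers stand for stronger inhibition of growth and higher numbers for weaker inhibition of growth), compound 1 `Oc1cccc2[nH]c(-c3ccc(-c4ccc(-c5ccc(C(F)(F)F)cc5)cc4)cc3)nc12` gives 3180 nM, compound 2 `Oc1cccc2[nH]c(-c3ccc(-c4ccc(-c5ccc(OC(F)(F)F)cc5)cc4)cc3)nc12` gives 3100 nM and compound 3 `COc1ccc(-c2ccc(-c3ccc(-c4nc5c(O)cccc5[nH]4)cc3)cc2)cc1` gives 6400 nM. Compound 3 thus lies within the scatter of compound 1, and only its gap to compound 2 passes the scatter. Compound 4 `Oc1cccc2[nH]c(-c3ccc(-c4ccc(-c5cccc(Cl)c5)cc4)cc3)nc12` puts 3-chlorophenyl in place of 4-methoxyphenyl (3-chlorophenyl in place of 4-methoxyphenyl on an aromatic carbon). Changing the end group has so far brought only small steps: a 2.0-fold higher number from compound 1 to compound 3 (0.30 log units; within the scatter) and a 2.1-fold higher number from compound 2 to compound 3 (0.31 log units; beyond the scatter). Among the measured compounds shown here, no measured compound carries a chlorine, so the range must stay wide. A modest shift towards the lower numbers of the compounds without methoxy seems likely, and the expected step is a 1.6-fold lower number from compound 3 to compound 4 (0.20 log units; within the scatter). For compound 4 the estimate is 4000 nM, with an expected range of 1800 nM to 9000 nM.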

Compound 4, concentration for 50% growth inhibition: 2100 nM
Estimate against measurement, compound 4: 1.9-fold (0.28 log units) above; the measured number falls inside the stated range.
By their numbers in this assay, from the lowest: compounds 4, 2, 1 and 3 (each within the scatter of the next, the first and the last beyond it).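

In this assay, the 3-chlorophenyl end group of compound 4 is the only one here carrying a chlorine, and its step from 4-methoxyphenyl passes the scatter (a 3.0-fold lower number from compound 3 to compound 4 (0.48 log units; beyond the scatter)). Against 4-(trifluoromethoxy)phenyl and 4-(trifluoromethyl)phenyl it stays within the scatter (a 1.5-fold lower number from compound 2 to compound 4 (0.17 log units; within the scatter); a 1.5-fold lower number from compound 1 to compound 4 (0.18 log units; within the scatter)), so of the three other compounds only compound 3 stands apart from compound 4. Nothing shown accounts for these steps. The kind of group and its place on the ring change together here, and 4-chlorophenyl would separate them. On these data alone, what an amine or a carboxylic acid on this end ring would do also stays open.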